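Replacing 4-acetamidophenyl with 2-chloropyridin-3-yl in a growth inhibition series

The compounds below may be only part of what the source reports. "The series", "measured", "known", "first", "only" and "open" are said of these compounds alone.

Measured in a functional assay on A549 cells (Homo sapiens) for inhibition, read by sulforhodamine B assay, with a stated time of 48 h, tested at 50 uM; a higher number here means more inhibition of growth at the concentration tested, a lower number less inhibition of growth:
- compound 1 `COc1ccc([C@@H]2C/C(=N/OCc3cn(-c4ccc(C#N)cc4)nn3)c3cc(CC=C(C)C)c(OC)cc3O2)cc1` gives 42%
- compound 2 `COc1ccc([C@@H]2C/C(=N/OCc3cn(-c4ccc(C(N)=O)cc4)nn3)c3cc(CC=C(C)C)c(OC)cc3O2)cc1` gives 100%
- compound 3 `COc1ccc([C@@H]2C/C(=N/OCc3cn(-c4ccc(NC(C)=O)cc4)nn3)c3cc(CC=C(C)C)c(OC)cc3O2)cc1` gives 19%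

Compound 3 gives 19%, which stands lowest of the three, and its gaps to both others lie beyond the scatter. Compound 4 `COc1ccc([C@@H]2C/C(=N/OCc3cn(-c4cccnc4Cl)nn3)c3cc(CC=C(C)C)c(OC)cc3O2)cc1` carries 2-chloropyridin-3-yl in place of 4-acetamidophenyl on an aromatic nitrogen. It therefore keeps neither the acetamido group of compound 3, the carbamoyl of compound 2 nor the cyano of compound 1.

Among the measured compounds shown here, three measured steps bear on this change, each exchanging one group on an aromatic carbon. They are large (a number 58 percentage points higher from compound 1 to compound 2 (beyond the scatter)), modest (a number 23 percentage points lower from compound 1 to compound 3 (beyond the scatter)) and large again (a number 81 percentage points lower from compound 2 to compound 3 (beyond the scatter)), and all lie beyond the scatter. None of them replaces the whole aromatic ring, so they offer only a rough guide to the size of the new step. Compound 3 sits at the bottom of the measured values, so a modest upward step is expected in this assay with wide uncertainty. The expected step is a rise (a number 21 percentage points higher from compound 3 to compound 4 (beyond the scatter)). Compound 4 is expected at 40% (estimated range 15% to 75%).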

Compound 4, percent growth inhibition at one concentration: 58%
Compound 4: the middle estimate sits 18 percentage points below what was measured, within the range that was stated.
By their numbers in this assay, from the lowest: compound 3; then compound 1; then compound 4; then compound 2.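

Exchanging the whole aromatic group on the triazole nitrogen, rather than a single substituent on it, still gives a clear change in this assay (a number 39 percentage points higher from compound 3 to compound 4 (beyond the scatter)). The 2-chloropyridin-3-yl group, with fewer heavy atoms than 4-acetamidophenyl and no hydrogen-bond donor, also improves on the 4-cyanophenyl group by a smaller margin (a number 16 percentage points higher from compound 1 to compound 4 (beyond the scatter)), yet it falls well short of the 4-carbamoylphenyl group (a number 42 percentage points lower from compound 2 to compound 4 (beyond the scatter)), so this position tolerates a ring with a hetero atom while the carbamoyl-bearing compound stays on top among these four. Nothing available explains why the four groups rank in this order.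

The ring nitrogen and the chlorine enter together in compound 4, so the compounds shown cannot separate their contributions, and an amine or a methyl in place of the chlorine would be needed to isolate the part played by the halogen. As far as these compounds go, it also remains open whether a carbamoyl group, the substituent of compound 2, would keep its high reading on the ring with a hetero atom.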